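Compound 2 to compound 4: (propylcarbonyl)oxy to methoxy

The source may hold more compounds than are shown below. What is called first, only, known or untested is meant among the compounds shown, and "the series" means these compounds.

In a functional assay on HeLa cells (Homo sapiens) for inhibition, with a stated time of 48 h, tested at 50 uM (a higher number here means more inhibition of growth at the concentration tested, a lower number less inhibition of growth), compound 1 `C=C[C@@](C)(/C=C/c1ccc(OC(=O)CC)cc1)CCC=C(C)C` reaches 48% at the tested concentration, compound 2 `C=C[C@@](C)(/C=C/c1ccc(OC(=O)CCC)cc1)CCC=C(C)C` reaches 36% and compound 3 `C=C[C@@](C)(/C=C/c1ccc(OC(=O)CCCCC)cc1)CCC=C(C)C` reaches 50% on the same read-out. Compound 2 stands lowest of the three.

Compound 4 `C=C[C@@](C)(/C=C/c1ccc(OC)cc1)CCC=C(C)C` differs from compound 2 as follows (methyl in place of propylcarbonyl on an oxygen on an aromatic ring): methyl in place of propylcarbonyl on an oxygen on an aromatic ring.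

The measured steps touch only the saturated chain (a number 12 percentage points lower from compound 1 to compound 2 (beyond the scatter); a number 14 percentage points higher from compound 2 to compound 3 (beyond the scatter); a number 2 percentage points higher from compound 1 to compound 3 (within the scatter)) and are modest or within the scatter. For the measured compounds named here, none of them replaces the carbonyl, so no measured step matches this change directly, and only their size serves as a guide. Compound 2 sits at the low end with 36% as its number, which favours a small rise over a fall. The expected step is none beyond the scatter (a number 6 percentage points higher from compound 2 to compound 4 (within the scatter)). For this assay compound 4 is estimated at 42% with a range from 26% to 58% as the expected span.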

Compound 4, percent growth inhibition at one concentration: 43%
Beside the measured number, compound 4's estimate is 1 percentage points below it; measured number inside the range.
By their numbers in this assay, from the lowest: compounds 2, 4, 1 and 3 (each within the scatter of the next, the first and the last beyond it).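

In this assay, the carbonyl turns out not to be required at this oxygen on an aromatic ring: methyl in place of propylcarbonyl gives a number 7 percentage points higher from compound 2 to compound 4 (within the scatter), methyl in place of pentylcarbonyl gives a number 7 percentage points lower from compound 3 to compound 4 (within the scatter), and methyl in place of propanoyl gives a number 5 percentage points lower from compound 1 to compound 4 (within the scatter). Removing the whole acyl group thus produces no step beyond the scatter, whereas two of the smaller chain changes among the esters did exceed it. No supporting data bear on why this exchange is tolerated.

Going by these compounds, a free hydroxyl on this aromatic ring, or a chain ending in an amine or a carboxylic acid on this oxygen, remains open. Also open, on these data alone, is whether the same picture would hold across a full concentration range rather than at the single tested concentration.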